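Changing the Benzyl Substituent: Compound 3 to Compound 4

The source may report more compounds than this note shows. Statements on the series, on what has been measured and on what is new or still open speak of the compounds shown alone.

Compound 3 `CSCC[C@H](NC(=O)c1ccc(NCc2cncn2Cc2ccccc2C#N)cc1-c1ccccc1)C(=O)O` belongs to a small set of three measured compounds. In a functional assay on NIH3T3 cells (Mus musculus) (on this read-out lower numbers stand for an effect already at smaller amounts and higher numbers for an effect only at larger amounts of compound), compound 3 gives > 10 uM, which is a limit of the assay rather than a number. Compound 1 `CSCC[C@H](NC(=O)c1ccc(NCc2cncn2Cc2ccccc2C)cc1-c1ccccc1)C(=O)O` gives > 10 uM in this assay, again a limit. Compound 2 `CSCC[C@H](NC(=O)c1ccc(NCc2cncn2Cc2cccc(Cl)c2)cc1-c1ccccc1)C(=O)O` likewise gives > 10 uM, also a limit. The steps a step that the two limits leave unreadable from compound 1 to compound 2, a step that the two limits leave unreadable from compound 1 to compound 3 and a step that the two limits leave unreadable from compound 2 to compound 3 cannot be read, since (the limit of > 10 uM in this assay, at which 3 of the 3 values shown sit). Compound 4 `CSCC[C@H](NC(=O)c1ccc(NCc2cncn2Cc2ccc(C)cc2)cc1-c1ccccc1)C(=O)O` differs from compound 3 by 4-methylphenyl in place of 2-cyanophenyl on a saturated chain carbon bound to an aromatic nitrogen. For the measured compounds named here, no measured step bears on this change, and none of the three values is a number. Compound 4 is therefore expected to stay near the same limit, a step that the limit leaves unreadable from compound 3 to compound 4, with an estimate of 15 uM ranging from 5 uM to 50 uM.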

Compound 4, concentration for half-maximal effect: > 10 uM
Compound 4: only a limit was reported; the forecaster's own chance of this, stated with the estimate: 70%; the middle value is on the limit's open side.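

Compound 4 also gives only a limit, so its steps from compound 1, compound 2 and compound 3 cannot be read: the limit of > 10 uM in this assay, at which 4 of the 4 values shown sit. The compounds shown leave open how strongly any of these four acts in this assay, and whether the benzyl substituent matters at all.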